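The source may hold more compounds than are shown below. What is called first, only, known or untested is meant among the compounds shown, and "the series" means these compounds.

Of the compounds shown here, three have so far been measured in a functional assay (trachea) for antagonist activity, with Cavia porcellus as the target; on this read-out lower numbers stand for lower potency and higher numbers for higher potency (the scale is a negative logarithm). Compound 1 `CCCCC(CC)C(=O)Nc1ccc2ccn(Cc3ccc(C(=O)NS(=O)(=O)c4ccc(Cl)cc4)cc3OC)c2c1` gives 7.8, the second highest of the three numbers. Compound 2 `CCCCC(CC)C(=O)Nc1ccc2cnn(Cc3ccc(-c4nn[nH]n4)cc3OC)c2c1` gives 7.1, which lies below compound 1 by more than the usual scatter, while compound 3 `COc1cc(C(=O)NS(=O)(=O)c2ccccc2N)ccc1Cn1ccc2ccc(NC(=O)CC3CCCC3)cc21` gives 9.9, far above compound 1 and also beyond the scatter. Compound 4 `CCCCC(CC)C(=O)Nc1ccc2ccn(Cc3ccc(C(=O)NS(=O)(=O)c4ccc(F)cc4)cc3OC)c2c1` has not yet been measured. It differs from compound 1 in a single place: fluoro in place of chloro on an aromatic carbon. Within the data shown here, no measured pair shows this exchange, so there is no direct precedent for its size. Such a swap of one halogen for another is expected to change this assay little, with at most a slight downward lean, and probably not beyond the scatter. Compound 4 is therefore expected to give 7.6, within a range from 7 to 8.2, an expected step of a number 0.20 log units lower from compound 1 to compound 4 (within the scatter).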

Compound 4, negative logarithm of the antagonist equilibrium constant: 7.7
The estimate for compound 4 lay 0.10 log units below the measured number; the range from low to high includes it.
By their numbers in this assay, from the lowest: compound 2; then compounds 4 and 1 (each within the scatter of the next); then compound 3.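

Fluoro in place of chloro, on an aromatic carbon para to a large group, gives a number 0.10 log units lower from compound 1 to compound 4 (within the scatter) in this assay. Among these compounds, this is the first direct reading of a change at this position, and this assay does not separate the two halogens here. Nothing measured beyond this assay bears on the result.

The compounds shown leave open whether the position tolerates only halogens. A bromo, methyl, nitrile or trifluoromethyl group in the same place, on the otherwise unchanged structure of compound 1, would test how far that tolerance extends.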